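From compound 3 to compound 4: a larger group arrives

This account rests on a few compounds, and the source may have more. Where it says the series, first, only, none or still open, it means among the compounds named here.

Measured in a physicochemical assay for solubility, measured as thermodynamic solubility, at pH 7.4 (a lower number here means a less soluble compound, a higher number a more soluble compound), so far:
Compound 1 `COCCNc1nc(NC(c2ccccc2)c2ccccc2)c2c(n1)C(=O)N(C(C)C)C2` gives < 1000 nM as a limit
Compound 2 `CC(=O)N1CCN(c2nc(NC(c3ccccc3)c3ccccc3)c3c(n2)C(=O)N(C(C)C)C3)CC1` gives < 1000 nM as a limit
Compound 3 `CC(=O)N1CCN(c2nc(NCc3ccccc3)c3c(n2)C(=O)N(C(C)C)C3)CC1` gives 230000 nM as a true number

Compound 3 is the only one of these with a true number. The other two compounds stand at the limit of < 1000 nM in this assay, at which 2 of the 3 values shown sit, and give no number.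

Compound 4 `CC(=O)N1CCN(c2nc(NCC3(c4ccc(Cl)cc4)CCC3)c3c(n2)C(=O)N(C(C)C)C3)CC1` has not yet been measured and differs from compound 3 in one group: 1-(4-chlorophenyl)cyclobutyl in place of phenyl on a saturated chain carbon bound to a nitrogen on an aromatic ring and so 1-(4-chlorophenyl)cyclobutyl stands in place of phenyl on the saturated chain carbon.

The step that the two limits leave unreadable from compound 1 to compound 2 has no readable size and offers no guide. The step that bears on this change is an at least 230-fold higher number from compound 2 to compound 3 (2.36 log units; beyond the scatter), in which hydrogen took the place of phenyl and the number rose. Going by that step, a change in the opposite direction is expected here, with more heavy atoms entering than leaving. The expected step is a 77-fold lower number from compound 3 to compound 4 (1.88 log units; beyond the scatter), large and toward a lower number. Compound 4 is estimated at 3000 nM, with an expected range of 300 nM to 30000 nM in this assay for now.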

Compound 4, solubility: 46000 nM
Compound 4: the middle estimate sits 15-fold (1.19 log units) below what was measured; measured number above the stated range.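

In this assay, 1-(4-chlorophenyl)cyclobutyl in place of phenyl on the saturated chain carbon gives a 5.0-fold lower number from compound 3 to compound 4 (0.70 log units; beyond the scatter), a modest step, though still beyond the scatter. This position therefore accepts a much larger group with a far smaller fall than the earlier step in the other direction, an at least 230-fold higher number from compound 2 to compound 3 (2.36 log units; beyond the scatter), would have suggested, although that step concerned a second phenyl on the chain carbon, a different kind of change. The size of that earlier step stays uncertain, as compound 2 gives a limit and not a number: the limit of < 1000 nM in this assay, at which 2 of the 4 values shown sit.

The compounds shown do not separate the part played by the chlorine from that of the four-membered ring. From the compounds shown here alone, how an amine or a carboxylic acid on the same ring would read also remains open.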